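The source may report more compounds than this note shows. Statements on the series, on what has been measured and on what is new or still open speak of the compounds shown alone.

Measured in a functional assay on MDA-MB-231 cells (Homo sapiens) for antiproliferative activity, read by MTT assay, with a stated time of 72 h; a higher number here means a weaker inhibitor, a lower number a stronger inhibitor:
Compound 1 `CCNC(=O)CCc1cccc2c1B(O)OC2`: > 100000 nM, a limit
Compound 2 `O=C(CCc1cccc2c1B(O)OC2)NC1CCCCC1`: > 100000 nM, a limit
Compound 3 `Cc1ccc(NC(=O)CCc2cccc3c2B(O)OC3)cc1`: 1100 nM

For the measured compounds named here, compound 3, at 1100 nM, holds the only true number in the set. Compound 4 `O=C(CCc1cccc2c1B(O)OC2)Nc1ccc(-c2ccccc2)cc1` replaces its methyl with phenyl on an aromatic carbon, para to a large group: phenyl in place of methyl on an aromatic carbon. Going by the values given here, two measured steps bear on this only indirectly, an at least 90-fold lower number from compound 1 to compound 3 (1.95 log units; beyond the scatter) and an at least 90-fold lower number from compound 2 to compound 3 (1.95 log units; beyond the scatter), both large and both made on the amide-type nitrogen. Among the compounds with values here, compound 4 keeps the aromatic ring introduced there, but no measured step changes the new position. In this assay, no shift beyond the scatter is therefore expected, and the estimated step is a 1.4-fold lower number from compound 3 to compound 4 (0.14 log units; within the scatter). Compound 4 is estimated at 800 nM, with an expected range of 150 nM to 5000 nM.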

Compound 4, half-maximal inhibitory concentration: 8800 nM
Compound 4: middle estimate off by 11-fold (1.04 log units), on the low side; the measured number lies above the stated range.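

In this assay, phenyl in place of methyl on an aromatic carbon, para to a large group, gives an 8.0-fold higher number from compound 3 to compound 4 (0.90 log units; beyond the scatter). For the compounds shown here, the earlier readable steps changed only the group on the amide-type nitrogen, so this is the first sign that the number also responds to a change on the aromatic ring, here moving towards a weaker inhibitor. Nothing given here accounts for this rise.

From the compounds shown here alone, how an amine, a carboxylic acid or a methoxy group would behave at this position remains open. So does whether a chlorine atom, smaller than phenyl, would keep the number of compound 3.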